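Sulfonyl aryl variation at a fixed methylpiperidine core

This account rests on a few compounds, and the source may have more. Where it says the series, first, only, none or still open, it means among the compounds named here.

Compound 1 `CC1CCN(c2c(S(=O)(=O)c3ccc(F)c(F)c3)cnc3cc(Cl)ccc23)CC1` gives 90% in an assay on isolated protein for displacement of a labelled ligand from metabotropic glutamate receptor 5 (Homo sapiens), with a stated time of 60 min, tested at 1 uM; on this read-out higher numbers stand for more inhibition at the one concentration tested (going by the name of the read-out) and lower numbers for less inhibition. Compound 2 `CC1CCN(c2c(S(=O)(=O)c3ccc(Cl)cc3)cnc3cc(Cl)ccc23)CC1` gives 91% in this assay, and the change from compound 1 is a number 1 percentage points higher from compound 1 to compound 2 (within the scatter). Compound 3 `COc1cccc(S(=O)(=O)c2cnc3cc(Cl)ccc3c2N2CCC(C)CC2)c1` gives 93% in this assay; it holds the highest of the three numbers, yet the steps of a number 3 percentage points higher from compound 1 to compound 3 (within the scatter) and a number 2 percentage points higher from compound 2 to compound 3 (within the scatter) are both within the scatter, so no order among the three can be stated. Compound 4 `CC1CCN(c2c(S(=O)(=O)c3cccc(C#N)c3)cnc3cc(Cl)ccc23)CC1` differs from compound 3 by cyano in place of methoxy on an aromatic carbon. Among the measured compounds shown here, the steps that bear on it are the three changes on the sulfonyl aryl, none of which left the scatter; a step of similar size is therefore expected, a number 3 percentage points lower from compound 3 to compound 4 (within the scatter). Compound 4 is estimated at 90% in this assay, in the range 80% to 97%.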

Compound 4, a percentage reported as inhibition, at one concentration (the size of the read-out at that concentration, not a potency): 94%
For compound 4 the middle estimate is 4 percentage points below the measured one; low and high end bracket the measured number.
By their numbers in this assay, from the lowest: compounds 1, 2, 3 and 4 (each within the scatter of the next).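

Cyano in place of methoxy on an aromatic carbon leaves the number level in this assay (a number 1 percentage points higher from compound 3 to compound 4 (within the scatter)). The wider comparisons, 3-cyanophenyl against the other two sulfonyl aryl groups, also stay within the scatter (a number 3 percentage points higher from compound 2 to compound 4 (within the scatter); a number 4 percentage points higher from compound 1 to compound 4 (within the scatter)). No measurement at hand accounts for this lack of separation.

As far as these compounds go, whether an amine or a carboxylic acid in place of the cyano would produce a step beyond the scatter remains open. Any potency order among these four compounds also remains open.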